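The compounds below may be only part of what the source reports. "The series", "measured", "known", "first", "only" and "open" are said of these compounds alone.

Measured so far in an assay on isolated protein for inhibition of sphingomyelin phosphodiesterase (Homo sapiens), read by fluorescence, with a stated time of 30 min; a higher number here means a weaker inhibitor, a lower number a stronger inhibitor:
Compound 1, `O=C(NO)c1cccc(OCc2ccc(-c3noc(-c4ccc(Br)cc4)n3)cc2)c1`, gives > 100000 nM, which is a limit of the assay and not a number.
Compound 2, `O=C(NO)c1cccc(OCc2ccc(-c3noc(-c4cccc(F)c4)n3)cc2)c1`, gives > 100000 nM, again a limit rather than a number.

Compound 2 thus stands at the ceiling of this assay, (the limit of > 100000 nM in this assay, at which 2 of the 2 values shown sit); compound 1 sits at the same place, so no order between the two can be read. Within the data shown here, the only measured step, a step that the two limits leave unreadable from compound 1 to compound 2, is left unreadable by the two limits, and it therefore offers no measure of how far an exchange on the aromatic carbon of the five-membered ring moves potency.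

Compound 3, `O=C(NO)c1cccc(OCc2ccc(-c3noc(CCc4ccccc4)n3)cc2)c1`, differs from compound 2 by phenethyl in place of 3-fluorophenyl on an aromatic carbon. Among the measured compounds shown here, no measured step bears on this exchange with a readable size, so the direction of the step in this assay cannot be inferred from the data. Because compound 2 gives > 100000 nM, only a limit, the expected step that the limit leaves unreadable from compound 2 to compound 3 is set near zero, with a wide range in either direction. Compound 3 is estimated at 150000 nM, between 30000 nM and 600000 nM, and it is expected most likely to be reported again as a limit.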

Compound 3, half-maximal inhibitory concentration: 1730 nM
The estimate for compound 3 lay 87-fold (1.94 log units) above the measured number; the whole stated range lies above it.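

This position on the five-membered ring turns out to matter, even though the exchange of one aryl group for another gave nothing to measure. In this assay, phenethyl in place of 3-fluorophenyl gives an at least 57-fold lower number from compound 2 to compound 3 (1.76 log units; beyond the scatter), and phenethyl in place of 4-bromophenyl gives an at least 57-fold lower number from compound 1 to compound 3 (1.76 log units; beyond the scatter). Compound 3 therefore gives the first readable number in the series, while the other compounds remain at the ceiling: the limit of > 100000 nM in this assay, at which 2 of the 3 values shown sit.

The group that leaves and the group that enters each carry one six-membered aromatic ring of carbon only and no hydrogen-bond donors or acceptors, so these counts do not separate active from inactive here, and the step between compound 1 and compound 2 cannot be read. From the compounds shown here alone, it remains open whether benzyl or a longer chain such as 3-phenylpropyl would do as well as phenethyl at this carbon, and whether a fluorine, a bromine or an amine on the phenethyl ring would move the number in either direction.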